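Capping the aromatic nitrogen of compound 1

The compounds below may be only part of what the source reports. "The series", "measured", "known", "first", "only" and "open" are said of these compounds alone.

Measured in a functional assay on A549 cells (Homo sapiens) for inhibition, read by CCK-8 assay, with a stated time of 48 h; a lower number here means a stronger inhibitor, a higher number a weaker inhibitor:
- compound 1 `COc1cc(-c2ccnc3cc(-c4c[nH]c5ccccc45)nn23)cc(OC)c1OC`: 29 nM
- compound 2 `COc1cc(-c2ccnc3cc(-c4cccc(C#N)c4)nn23)cc(OC)c1OC`: > 10000 nM (a limit of the assay)
- compound 3 `COc1cc(-c2ccnc3cc(-c4ccc5ccn(C)c5c4)nn23)cc(OC)c1OC`: 829 nM

Compound 1 holds the lowest number of those shown. Compound 4 `COc1cc(-c2ccnc3cc(-c4cn(C(=O)OC(C)(C)C)c5ccccc45)nn23)cc(OC)c1OC` differs from it in one place: tert-butoxycarbonyl in place of hydrogen on an aromatic nitrogen. Going by the values given here, no measured step changes this aromatic nitrogen alone. The closest evidence comes from replacing the whole 1H-indol-3-yl group, which gave a 29-fold higher number from compound 1 to compound 3 (1.46 log units; beyond the scatter) and an at least 340-fold higher number from compound 1 to compound 2 (2.53 log units; beyond the scatter). Both steps are large and both raise the number, but each changes more of the structure than compound 4 does. A smaller rise, still beyond the scatter, is therefore expected in this assay. This would be an expected 17-fold higher number from compound 1 to compound 4 (1.24 log units; beyond the scatter). For compound 4 the estimated value is 500 nM, with an expected range of 70 nM to 5000 nM.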

Compound 4, half-maximal inhibitory concentration: 2070 nM
Compound 4: middle estimate off by 4.1-fold (0.62 log units), on the low side; measured number inside the range.
By their numbers in this assay, from the lowest: compound 1; then compound 3; then compound 4. At a limit, above all of these: compound 2.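

In this assay tert-butoxycarbonyl in place of hydrogen on the aromatic nitrogen gives a 71-fold higher number from compound 1 to compound 4 (1.85 log units; beyond the scatter), so a change at this nitrogen alone, with the rest of the 1H-indol-3-yl group kept, is enough for a large rise. The earlier compounds shown here replaced the whole group and could not show this. Nothing measured here accounts for the rise.

One substituent on this nitrogen cannot tell whether any replacement of the hydrogen raises the number or only this one. On these data alone, whether a methyl or an acetyl group there would give a step of similar size stays open.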